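Fluoro in Place of Methoxy: An Expected Limit

A few compounds are considered here, and "the series" means these few. Any claim that something is new, unique, unknown or untested is made for them only; others in the source may bear on it.

compound 2 `CCC1(CCCCN2CCN(c3ccc(OC)cc3)CC2)C(=O)Nc2ccccc21`: > 20 mg/kg
compound 1 `CCC1(CCCCN2CCN(c3cccc(Cl)c3)CC2)C(=O)Nc2c(Cl)cc(Cl)cc21`: > 20 mg/kg
compound 3 `CCC1(CCCCN2CCN(c3ccc(Cl)cc3)CC2)C(=O)Nc2cc(F)ccc21`: > 20 mg/kg

In a functional assay on the whole organism (strain Wistar) with Rattus norvegicus as the target, with a stated time of 5 min (a higher number here means that more compound is needed for the effect, a lower number that less compound is needed), compound 2 gives > 20 mg/kg, and this is a limit of the assay, not a number. Compound 1 likewise reaches only the limit > 20 mg/kg. Compound 3 also stops at the limit > 20 mg/kg. So compound 2 stands exactly where every measured compound stands: the limit of > 20 mg/kg in this assay, at which 3 of the 3 values shown sit. Among the measured compounds shown here, no step between two measured compounds is known, so nothing yet shows how any single change moves this read-out.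

Compound 4 `CCC1(CCCCN2CCN(c3ccc(F)cc3)CC2)C(=O)Nc2ccccc21` differs from compound 2 in one place: fluoro in place of methoxy on an aromatic carbon. With all three measured values sitting at the same limit, the expectation for this step is no move beyond the usual scatter, and the most likely outcome for compound 4 is once more a limit. The expected step that the limit leaves unreadable from compound 2 to compound 4 is therefore about none. Compound 4 is estimated at 30 mg/kg, between 10 mg/kg and 100 mg/kg.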

Compound 4, minimum effective dose: 10 mg/kg
Beside the measured number, compound 4's estimate is 3.0-fold (0.48 log units) above it, and the stated range covers the measured number.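

In this assay compound 4 gives 10 mg/kg, the first result in this set that is a number and not a limit. As far as these compounds go, the change from 4-methoxyphenyl to 4-fluorophenyl can be read only as a floor, an at least 2.0-fold lower number from compound 2 to compound 4 (0.30 log units; that floor lies within the scatter), so the true size of the step stays unknown. Even so, this position can carry a group that gives a measured dose, which the earlier compounds could not show, as all of them stop at the same limit: the limit of > 20 mg/kg in this assay, at which 3 of the 4 values shown sit.

Still open, from the compounds shown here alone, is how other groups at this place, such as a hydroxyl, a nitrile or a trifluoromethyl, or plain hydrogen, would read in this test. Also open, going by these compounds, is whether a shorter or longer chain in compound 4 would lower or raise the dose needed.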